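The source may report more compounds than this note shows. Statements on the series, on what has been measured and on what is new or still open speak of the compounds shown alone.

The measured compounds:
compound 1, `CN1CCN(c2nc(-c3cccc(Cl)c3)nc3[nH]cnc23)CC1`, giving > 80%
compound 2, `Clc1ccc(-c2nc(N3CCCCC3)c3nc[nH]c3n2)cc1Cl`, giving 24.1%
compound 3, `Clc1ccc(-c2nc(N3CCCCC3)c3nc[nH]c3n2)cc1`, giving > 80%

All three were tested in an assay on cells for displacement of a labelled ligand from adenosine receptor A1 (Homo sapiens), read by scintillation counting and radioligand binding, with a stated time of 60 min, tested at 10 uM; a lower number here means less inhibition, a higher number more inhibition at the concentration tested (going by the name of the read-out). The value of compound 1 is a limit of the assay, not a number. The value of compound 3 is likewise a limit. Only compound 2 gives a plain number in this assay.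

Compound 3 and compound 2 differ in one place: chloro in place of hydrogen on an aromatic carbon. This single change made a number at least 55.9 percentage points lower from compound 3 to compound 2 (beyond the scatter).

Compound 1 and compound 3 differ in more than one place, and the difference between the two cores is not broken down here.

Compound 4, `CN1CCN(c2nc(-c3cc(Cl)ccc3Cl)nc3[nH]cnc23)CC1`, is not yet measured in this assay. It stands to compound 1 as compound 2 stands to compound 3: chloro in place of hydrogen on an aromatic carbon. The place is not the same, though. In compound 2 the entering chloro sits ortho to a chloro group and meta to a large group, while in compound 4 it sits ortho to a large group and para to a chloro group, so this is the same kind of change rather than the same change. Of the three values, two sit at the limit of > 80% in this assay, at which 2 of the 3 values shown sit, so the starting point of compound 1 is known only as a limit.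

The expectation for compound 4 rests on the measured step of a number at least 55.9 percentage points lower from compound 3 to compound 2 (beyond the scatter), tempered by the different surroundings of the new chloro. Compound 4 is expected to give about 40%, an estimated step of a number at least 40 percentage points lower from compound 1 to compound 4 (beyond the scatter). Compound 4 is estimated to fall between 10% and 80%.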

Compound 4, a percentage reported as inhibition, at one concentration (the size of the read-out at that concentration, not a potency): > 80%
Compound 4: only a limit was reported (the forecaster's own chance of this, stated with the estimate: 15%); middle value at least 40 percentage points from the limit.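

In this assay compound 1 gives > 80%, which is a limit and not a number. Compound 4 gives > 80%, also a limit. No step from one compound to the other can be read, because both values sit at the same limit: the limit of > 80% in this assay, at which 3 of the 4 values shown sit.

The compounds shown leave open whether the added chloro changes the inhibition of compound 4 relative to compound 1 at all, and if so, by how much.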